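This account rests on a few compounds, and the source may have more. Where it says the series, first, only, none or still open, it means among the compounds named here.

Compound 1 `Cc1ccc(C(=O)NNC(=S)Nc2csc(-c3ccc(C)cc3)c2)cc1`: 37000 nM in a functional assay on A549 cells (Homo sapiens) for inhibition, read by colorimetric assay and MTT assay, with a stated time of 72 h; a lower number here means a stronger inhibitor, a higher number a weaker inhibitor.
Compound 2 `COc1ccc(C(=O)NNC(=S)Nc2csc(-c3ccc(C)cc3)c2)cc1`: 11000 nM in this assay.
Compound 3 `Cc1ccc(-c2cc(NC(=S)NNC(=O)c3ccc(O)cc3)cs2)cc1`: 44000 nM in this assay.

Among these three, compound 2 gives the lowest number in this assay, its nearest neighbour being compound 1 at a 3.4-fold lower number from compound 1 to compound 2 (0.53 log units; beyond the scatter) away, and compound 3 further off, a 4.0-fold higher number from compound 2 to compound 3 (0.60 log units; beyond the scatter). Compound 4 `COc1ccc(C(=O)NNC(=S)Nc2csc(-c3ccc(C)cc3)c2)cc1OC` differs from compound 2 by methoxy in place of hydrogen on an aromatic carbon. Within the data shown here, no measured step repeats this exact change; the closest are the methoxy-for-methyl step, a 3.4-fold lower number from compound 1 to compound 2 (0.53 log units; beyond the scatter), and the hydroxy-for-methoxy step, a 4.0-fold higher number from compound 2 to compound 3 (0.60 log units; beyond the scatter), both modest. A second methoxy is therefore expected to move the number little, perhaps not beyond the scatter, with a 1.2-fold lower number from compound 2 to compound 4 (0.09 log units; within the scatter) as the estimated step. Compound 4 is thus expected to give 9000 nM in this assay, within a range from 3500 nM to 25000 nM.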

Compound 4, half-maximal inhibitory concentration: 36000 nM
Beside the measured number, compound 4's estimate is 4.0-fold (0.60 log units) below it; the measured number lies above the stated range.
By their numbers in this assay, from the lowest: compound 2; then compounds 4, 1 and 3 (each within the scatter of the next).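

Placing a second methoxy on an aromatic carbon ortho to a methoxy group gives a 3.3-fold higher number from compound 2 to compound 4 (0.51 log units; beyond the scatter) in this assay. Among these compounds, this is the first step here that replaces a hydrogen on this ring rather than swapping a group already present, and it shows that this position does not simply accept a further methoxy. Nothing available explains this shift.

As far as these compounds go, it remains open whether an amine or a carboxylic acid at this carbon would move the number the same way. Also open, from the compounds shown here alone, is whether the rise depends on the methoxy already on the ring.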